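A longer ester chain on the shared core and cytotoxicity

A few compounds are considered here, and "the series" means these few. Any claim that something is new, unique, unknown or untested is made for them only; others in the source may bear on it.

Compound 1 `CCCCC(=O)OCCc1c(-c2ccccc2Cl)c2cc(Cl)ccc2[nH]c1=O` carries a butyl ester on the shared core. In an ADME assay on HepG2 2.2.15 cells (Homo sapiens) for cytotoxicity (a higher number here means that more compound is tolerated, a lower number that less compound is tolerated), compound 1 gives 200000 nM, the highest of the three numbers recorded. Compound 2 `N#CCC(=O)OCCc1c(-c2ccccc2Cl)c2cc(Cl)ccc2[nH]c1=O` gives 100000 nM and compound 3 `O=C(OCCc1c(-c2ccccc2Cl)c2cc(Cl)ccc2[nH]c1=O)c1ccco1` gives 98000 nM. The step of a 2.0-fold lower number from compound 1 to compound 2 (0.30 log units; within the scatter) lies within the scatter, whereas a 2.0-fold lower number from compound 1 to compound 3 (0.31 log units; beyond the scatter) is a modest step beyond it; a 1.0-fold lower number from compound 2 to compound 3 (0.01 log units; within the scatter) shows no difference between those two.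

Compound 4 `O=C(CCOc1ccccc1)OCCc1c(-c2ccccc2Cl)c2cc(Cl)ccc2[nH]c1=O` is not yet measured. It differs from compound 1 by phenoxy in place of ethyl on a saturated chain carbon, two bonds along the chain from a carbonyl carbon, which, cut one bond further out, reads butyl to 2-phenoxyethyl. The two steps that bear on it both replace part of the ester chain, and the one that brings in an aromatic ring, a 2.0-fold lower number from compound 1 to compound 3 (0.31 log units; beyond the scatter), gave a modest fall. Compound 4 is therefore expected to come in a little lower than compound 1, with a 2.0-fold lower number from compound 1 to compound 4 (0.30 log units; within the scatter) as the estimated step. The estimate for compound 4 is 100000 nM, within a range of 40000 nM to 250000 nM.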

Compound 4, half-maximal cytotoxic concentration: 46000 nM
For compound 4 the middle estimate is 2.2-fold (0.34 log units) above the measured one; the measured number falls inside the stated range.
By their numbers in this assay, from the lowest: compound 4; then compounds 3, 2 and 1 (each within the scatter of the next, the first and the last beyond it).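

In this assay, within the data shown here, compound 4 is the first ester whose steps to all the others lie beyond the scatter, which places it lowest of the four: a 4.3-fold lower number from compound 1 to compound 4 (0.64 log units; beyond the scatter), a 2.2-fold lower number from compound 2 to compound 4 (0.34 log units; beyond the scatter) and a 2.1-fold lower number from compound 3 to compound 4 (0.33 log units; beyond the scatter). The position therefore allows a larger fall than the earlier changes showed, and 2-phenoxyethyl on the carbonyl carbon goes lower than furan-2-yl there, although all of these values remain high on the scale of this series. No measurement shown gives a reason for this fall.

The compounds shown do not separate the phenyl ring from the ether oxygen, which a 4-phenylbutyl ester could address. On these data alone, whether an amine or a carboxylic acid at the end of the chain would move the number in the same way also remains open.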